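Removing the fluoro of compound 1: working expectation

This account rests on a few compounds, and the source may have more. Where it says the series, first, only, none or still open, it means among the compounds named here.

In a functional assay on A549 cells (Homo sapiens) for inhibition, read by sulforhodamine B assay, with a stated time of 48 h (on this read-out lower numbers stand for stronger inhibition and higher numbers for weaker inhibition), compound 1 `O=c1c([C@@H]2C[C@H](c3ccccc3)ON2c2ccccc2)coc2ccc(F)cc12` gives 51500 nM, the higher of the two numbers obtained so far. Compound 2 `COC(=O)[C@@]1(C)C[C@@H](c2coc3ccc(F)cc3c2=O)N(c2ccccc2)O1` gives 20300 nM in this assay, a value that lies beyond the scatter from that of compound 1. Compound 3 `Cc1ccc2occ([C@@H]3[C@H]4C(=O)N(c5ccccc5)C(=O)[C@H]4ON3c3ccccc3)c(=O)c2c1` gives > 60000 nM in this assay, which is a limit and not a number. Compound 4 `O=c1c([C@@H]2C[C@H](c3ccccc3)ON2c2ccccc2)coc2ccccc12` differs from compound 1 by hydrogen in place of fluoro on an aromatic carbon. Going by the values given here, no measured pair in the set isolates such a change, so no measured step can be pointed to. The expectation is a step of small size, not clearly beyond the scatter in either direction. Compound 4 is expected in this assay at 55000 nM, within a range from 25000 nM to 120000 nM. The estimated step is a 1.1-fold higher number from compound 1 to compound 4 (0.03 log units; within the scatter).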

Compound 4, half-maximal inhibitory concentration: > 60000 nM
Compound 4: only a limit was reported (the forecaster's own chance of this, stated with the estimate: 40%); at least 1.0-fold (0.03 log units) between middle value and limit.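

In this assay, hydrogen in place of fluoro on this aromatic carbon gives the series its first matched step: an at least 1.1-fold higher number from compound 1 to compound 4 (0.06 log units; that floor lies within the scatter). Compound 4 is reported only as a limit, so the step has a floor but no measured size, and it may be larger: the limit of > 60000 nM in this assay, at which 2 of the 4 values shown sit. This pair alone therefore does not show whether the fluoro of compound 1 matters.

Still open, going by these compounds, is whether chlorine, a methoxy group or an amine at this carbon would give a number rather than a limit. Also open, on these data alone, is whether removing the fluoro from compound 2 would give a comparable step.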